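Notes on compound 4: ethoxy to allyloxy

The source may hold more compounds than are shown below. What is called first, only, known or untested is meant among the compounds shown, and "the series" means these compounds.

compound 1 `CCOc1ccc2c(Cl)ccnc2c1` — 3340 nM
compound 2 `CCOc1ccc2c(NCCN(C)C)ccnc2c1` — 3490 nM
compound 3 `Clc1ccnc2cc(OCCCc3ccccc3)ccc12` — 630 nM

In a functional assay on NCI-H1650 cells (Homo sapiens) for cytotoxicity, read by MTT assay, with a stated time of 48 h (on this read-out higher numbers stand for weaker inhibition and lower numbers for stronger inhibition), compound 1 gives 3340 nM, the second highest of the three numbers. Compound 2 sits within the scatter of it (a 1.0-fold higher number from compound 1 to compound 2 (0.02 log units; within the scatter)), while compound 3 lies beyond it (a 5.3-fold lower number from compound 1 to compound 3 (0.72 log units; beyond the scatter)). Compound 4 `C=CCOc1ccc2c(Cl)ccnc2c1` differs from compound 1 by vinyl in place of methyl on a saturated chain carbon bound to an oxygen on an aromatic ring. For the measured compounds named here, the only measured step that touches the chain on the ring oxygen is the benzyl addition two bonds along, which gave a modest lowering; ethyl to allyl is a far smaller change, and the step at the other position gave nothing beyond the scatter. A step near or inside the scatter is therefore expected, leaning lower if anywhere. Compound 4 is expected to give 2800 nM, in the range 1200 nM to 6500 nM, a step of a 1.2-fold lower number from compound 1 to compound 4 (0.08 log units; within the scatter).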

Compound 4, half-maximal inhibitory concentration: 2280 nM
Estimate against measurement, compound 4: 1.2-fold (0.09 log units) above; measured number inside the range.
By their numbers in this assay, from the lowest: compound 3; then compounds 4, 1 and 2 (each within the scatter of the next).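

Ethyl to allyl on the ring oxygen gives a 1.5-fold lower number from compound 1 to compound 4 (0.17 log units; within the scatter), so vinyl in place of methyl at this place leaves the number inside the scatter. Among the changes to this chain, only the benzyl step, a 5.3-fold lower number from compound 1 to compound 3 (0.72 log units; beyond the scatter), lies beyond it. Nothing available explains the size of either step.

The compounds shown do not separate the extra carbon from the double bond, which a propoxy chain would address. Also open, as far as these compounds go, is whether an amine at the end of a longer chain on the ring oxygen would move the number.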